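The source may hold more compounds than are shown below. What is called first, only, known or untested is meant among the compounds shown, and "the series" means these compounds.

Measured in a functional assay on RS4-11 cells (Homo sapiens) for inhibition, read by CCK-8 assay, with a stated time of 72 h; a lower number here means a stronger inhibitor, a higher number a weaker inhibitor:
- compound 1 `CN1CCC(CNc2ccc(S(=O)(=O)NC(=O)c3ccc(N4CCN(CC5=C(c6ccc(C(F)(F)F)cc6)CC(C)(C)CC5)CC4)cc3Oc3cnc4[nH]ccc4c3)cc2[N+](=O)[O-])C1`: 8.3 nM
- compound 2 `CC1(C)CCC(CN2CCN(c3ccc(C(=O)NS(=O)(=O)c4ccc(OCC5CCSCC5)c([N+](=O)[O-])c4)c(Oc4cnc5[nH]ccc5c4)c3)CC2)=C(c2ccc(C(F)(F)F)cc2)C1`: 15 nM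
- compound 3 `CC(Oc1ccc(S(=O)(=O)NC(=O)c2ccc(N3CCN(CC4=C(c5ccc(C(F)(F)F)cc5)CC(C)(C)CC4)CC3)cc2Oc2cnc3[nH]ccc3c2)cc1[N+](=O)[O-])C1CCOCC1`: 269 nM

Compound 3 has the highest number of the three, and its steps to both others lie beyond the scatter. Compound 4 `CCN1CCC(COc2ccc(S(=O)(=O)NC(=O)c3ccc(N4CCN(CC5=C(c6ccc(C(F)(F)F)cc6)CC(C)(C)CC5)CC4)cc3Oc3cnc4[nH]ccc4c3)cc2[N+](=O)[O-])CC1` differs from compound 3 in one place: (1-ethylpiperidin-4-yl)methyl in place of 1-(oxan-4-yl)ethyl on an oxygen on an aromatic ring. In words, (1-ethylpiperidin-4-yl)methyl stands in place of 1-(oxan-4-yl)ethyl on an oxygen on an aromatic ring.

The closest measured change is an 18-fold higher number from compound 2 to compound 3 (1.25 log units; beyond the scatter), where 1-(oxan-4-yl)ethyl replaces (thian-4-yl)methyl on that same oxygen. The change a 32-fold higher number from compound 1 to compound 3 (1.51 log units; beyond the scatter) is also large, although its leaving group differs more. Among the measured compounds shown here, no measured compound carries the entering group, so the comparison is indirect. Compound 4 keeps a ring on a methyl, as compound 2 does, so a large move toward a lower number is expected, perhaps somewhat short of the full reverse of these steps. The expected change is an 11-fold lower number from compound 3 to compound 4 (1.03 log units; beyond the scatter). For compound 4 the estimated value is 25 nM, with an expected range from 7 nM to 90 nM.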

Compound 4, half-maximal inhibitory concentration: 4.9 nM
Compound 4: the middle estimate sits 5.1-fold (0.71 log units) above what was measured; measured number below the stated range.
By their numbers in this assay, from the lowest: compounds 4, 1 and 2 (each within the scatter of the next, the first and the last beyond it); then compound 3.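

In this assay, (1-ethylpiperidin-4-yl)methyl on this oxygen gives a 55-fold lower number from compound 3 to compound 4 (1.74 log units; beyond the scatter), the largest step among these compounds, and it shows that this oxygen can carry a ring nitrogen without any penalty. Among the compounds shown here, with the methyl link kept, changing only the ring gives a 3.1-fold lower number from compound 2 to compound 4 (0.49 log units; beyond the scatter), a modest step beyond the scatter that the earlier compounds could not isolate. An oxygen link also matches the amine link of compound 1, with a 1.7-fold lower number from compound 1 to compound 4 (0.23 log units; within the scatter) lying within the scatter, though no measurement here explains any of these steps. Compound 3 differs from compound 2 in both ring and branch, so (oxan-4-yl)methyl would be needed to separate the two. From the compounds shown here alone, whether the ethyl on the ring nitrogen matters remains open, and a 1-methylpiperidin-4-yl or unsubstituted piperidin-4-yl ring would test this.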